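Trimethylsilyl removal on the ethynyl sulfonamide: compound 4

This account rests on a few compounds, and the source may have more. Where it says the series, first, only, none or still open, it means among the compounds named here.

The measured compounds, each with its read-out in a functional assay on A-375 cells (Homo sapiens) for antiproliferative activity, read by trypan blue exclusion, with a stated time of 48 h, tested at 1 uM; a lower number here means a stronger effect, a higher number a weaker effect of the compound at the concentration tested:
Compound 1 `CC(=O)Nc1nc(-c2cccc(NS(=O)(=O)c3ccc(Br)cc3)c2)cs1`: compound 1 gives "not active" (no number reported).
Compound 2 `CC(=O)Nc1nc(-c2cccc(NS(=O)(=O)c3cccc(C#CCO)c3)c2)cs1`: compound 2 gives 85.4%.
Compound 3 `CC(=O)Nc1nc(-c2cccc(NS(=O)(=O)c3cccc(C#C[Si](C)(C)C)c3)c2)cs1`: compound 3 gives 61.6%.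

Compound 3 stands lowest of the two numbers, with compound 2 the nearest and higher by a step beyond the scatter, while compound 1 carries no number at all. Within the data shown here, the only step between two measured compounds is a number 23.8 percentage points lower from compound 2 to compound 3 (beyond the scatter), which was modest.

Compound 4 `C#Cc1cccc(S(=O)(=O)Nc2cccc(-c3csc(NC(C)=O)n3)c2)c1` differs from compound 3 by a hydrogen atom in place of a group of 4 heavy atoms (3 carbon, 1 silicon; no ring), on a triple-bonded carbon. Among the measured compounds shown here, no measured step removes the same group of 4 heavy atoms (3 carbon, 1 silicon; no ring); the step from compound 2 to compound 3 only shows that changing what sits on the triple-bonded carbon moved the number modestly. A modest upward step, or none beyond the scatter, is therefore expected: compound 4 is estimated at 72% (range 52% to 92%), meaning an expected a number 10.4 percentage points higher from compound 3 to compound 4 (beyond the scatter).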

Compound 4, a percentage reported as activity, at one concentration (the size of the read-out at that concentration, not a potency): 74.3%
Compound 4: the middle estimate sits 2.3 percentage points below what was measured, and the stated range covers the measured number.
By their numbers in this assay, from the lowest: compound 3; then compound 4; then compound 2.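

Compound 4 gives this position its unsubstituted reference: in this assay, hydrogen in place of the group of 4 heavy atoms (3 carbon, 1 silicon) gives a number 12.7 percentage points higher from compound 3 to compound 4 (beyond the scatter) and hydrogen in place of hydroxymethyl gives a number 11.1 percentage points lower from compound 2 to compound 4 (beyond the scatter). The two groups on the triple-bonded carbon therefore move the number in opposite directions from hydrogen, so across compound 2, compound 3 and compound 4 the read-out does not follow the count of heavy atoms in the group. Nothing available accounts for these differences. The compounds shown leave open how an amine, a carboxylic acid or a longer chain on the triple-bonded carbon would compare with hydrogen. They also leave open whether these differences would hold at other concentrations.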